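Series notes: triazolopyrimidine thioethers in a cell growth assay

A few compounds are considered here, and "the series" means these few. Any claim that something is new, unique, unknown or untested is made for them only; others in the source may bear on it.

Measured so far:
- compound 1, `Cc1cc(Nc2cc(-c3ccccc3)[nH]n2)n2nc(SCc3c(Cl)cccc3Cl)nc2n1`: 5180 nM
- compound 2, `Cc1cc(Nc2ccn(Cc3nc(C)c4ccccc4n3)n2)n2nc(SCc3ccc(Br)cc3)nc2n1`: 5450 nM
- compound 3, `Cc1cc(Nc2cc(-c3cccs3)[nH]n2)n2nc(SCc3ccc(Br)cc3)nc2n1`: 4890 nM

All three values come from a functional assay on PC-9 cells (Homo sapiens) for inhibition, read by MTT assay, with a stated time of 72 h; on this read-out higher numbers stand for weaker inhibition and lower numbers for stronger inhibition. Compound 1 gives 5180 nM, and its gaps to compound 2 and to compound 3 both lie within the scatter of repeated measurements, so the three compounds cannot be told apart on these numbers; the different groups at the sulfur and at the pyrazole have not moved the read-out beyond the scatter here.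

Compound 4, `C=CCSc1nc2nc(C)cc(Nc3cc(-c4ccccc4)[nH]n3)n2n1`, has not yet been measured. It differs from compound 1 at the sulfur-bound chain carbon: vinyl in place of 2,6-dichlorophenyl on a saturated chain carbon bound to a sulfur. Put another way, (2,6-dichlorobenzyl)sulfanyl becomes allylsulfanyl.

Within the data shown here, no measured pair shows this change, and nothing among the three compounds speaks for a large shift in either direction. The expectation is a modest weakening, amounting to a 1.4-fold higher number from compound 1 to compound 4 (0.16 log units; within the scatter) in this assay. Compound 4 is therefore estimated at 7500 nM, with a plausible range from 2500 nM to 22000 nM.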

Compound 4, half-maximal inhibitory concentration: > 50000 nM
Compound 4 was reported as a limit (the forecaster's own chance of this, stated with the estimate: 15%); at least 6.6-fold (0.82 log units) between middle value and limit.
By their numbers in this assay, from the lowest: compounds 3, 1 and 2 (each within the scatter of the next). At a limit, above all of these: compound 4.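

In this assay, compound 4 is reported only as a limit, > 50000 nM. Going from 2,6-dichlorobenzyl to allyl on the sulfur gives an at least 9.6-fold higher number from compound 1 to compound 4 (0.98 log units; beyond the scatter), the first step in the series that lies beyond the scatter, whereas the three earlier compounds could not be told apart and offered no one-place comparison. This position is therefore not indifferent to the group it carries, though the full size of the step cannot be read from a limit: the limit of > 50000 nM in this assay, at which 1 of the 4 values shown sits.

With only this one replacement shown, the data do not separate the loss of the aromatic ring from the loss of its two chlorines or from the shorter group. From the compounds shown here alone, an unsubstituted benzyl or a longer saturated chain such as n-butyl on the sulfur, with the rest of compound 1 unchanged, remains open.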